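The source may report more compounds than this note shows. Statements on the series, on what has been measured and on what is new or still open speak of the compounds shown alone.

Compound 1 `c1cncc(N2CC[C@H]3CN[C@H]3C2)c1` is the starting point. In a functional assay on HEK293 cells for agonist activity at Neuronal acetylcholine receptor; alpha3/beta4 (Homo sapiens), read by FLIPR (on this read-out lower numbers stand for an effect already at smaller amounts and higher numbers for an effect only at larger amounts of compound), compound 1 gives 48 nM, the lowest of the three numbers recorded so far. Its mirror image, compound 2 `c1cncc(N2CC[C@@H]3CN[C@@H]3C2)c1`, gives 260 nM, a step of a 5.4-fold higher number from compound 1 to compound 2 (0.73 log units; beyond the scatter). Compound 3 `N#Cc1cncc(N2CC[C@H]3CN[C@H]3C2)c1` carries a cyano group on the aromatic ring and gives 1000 nM, a step of a 21-fold higher number from compound 1 to compound 3 (1.32 log units; beyond the scatter).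

Compound 4 `COc1ccc(N2CC[C@H]3CN[C@H]3C2)cn1` differs from compound 1 by methoxy in place of hydrogen on an aromatic carbon. The step from compound 1 to compound 3 is the one that bears on it, since both add a group to the same aromatic ring; that step was large and weakening. A weakening is therefore expected for compound 4, though a methoxy group is not a cyano group, so a smaller step of a 3.1-fold higher number from compound 1 to compound 4 (0.49 log units; beyond the scatter) is estimated. Compound 4 is expected to give 150 nM, within a range of 50 nM to 500 nM.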

Compound 4, half-maximal effective concentration: 1100 nM
Estimate against measurement, compound 4: 7.3-fold (0.87 log units) below, outside the stated range (above it).
By their numbers in this assay, from the lowest: compound 1; then compound 2; then compounds 3 and 4 (each within the scatter of the next).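

Methoxy on an aromatic carbon next to the ring nitrogen, para to a group of 8 heavy atoms, gives a large step, a 23-fold higher number from compound 1 to compound 4 (1.36 log units; beyond the scatter). Cyano in compound 3 was therefore not the only ring addition to give a large step, and among the compounds shown, none with an added ring group comes close to compound 1. Nothing measured here accounts for the size of this step.

Going by these compounds, whether any group at this place gives so large a step, or methoxy in particular, stays open. A methyl, a chlorine or an amine there could separate the two cases.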